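A few compounds are considered here, and "the series" means these few. Any claim that something is new, unique, unknown or untested is made for them only; others in the source may bear on it.

Two boronic acid compounds have been measured so far in a functional assay on HeLa cells (Homo sapiens) for inhibition, read by MTT assay, with a stated time of 72 h; a higher number here means a weaker inhibitor, a lower number a stronger inhibitor. Compound 1 (`CC(C)C[C@H](NC(=O)CC[C@H](NC(=O)[C@H](C)NC(=O)OC(C)(C)C)C(=O)NCc1ccc2ccccc2c1)B(O)O`) gives 2350 nM, and compound 2 (`CC(C)C[C@H](NC(=O)CC[C@H](NC(=O)CNC(=O)OC(C)(C)C)C(=O)NCc1ccccc1)B(O)O`) gives 5110 nM. Compound 2 therefore stands as the higher number of the two, the weaker inhibitor, with a gap to compound 1 that lies beyond the usual scatter.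

Compound 3 (`CC(C)C[C@H](NC(=O)CC[C@H](NC(=O)CNC(=O)OC(C)(C)C)C(=O)NCc1ccc2ccccc2c1)B(O)O`) is built from compound 2 by one change: naphthalen-2-yl in place of phenyl on a saturated chain carbon bound to an amide-type nitrogen. Among the measured compounds shown here, no measured pair shows this change alone, so any expectation rests on thin evidence. Compound 1 also bears naphthalen-2-yl, and its value of 2350 nM suggests that compound 3 could move somewhat toward stronger inhibition, though compound 1 is not a clean comparison. The estimated step, a 1.7-fold lower number from compound 2 to compound 3 (0.23 log units; within the scatter), is therefore small and is expected to stay within the usual scatter. For compound 3 the expected value is 3000 nM, with an estimated range from 1300 nM to 6500 nM.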

Compound 3, half-maximal inhibitory concentration: 350 nM
Compound 3: the middle estimate sits 8.6-fold (0.93 log units) above what was measured, outside the stated range (below it).
By their numbers in this assay, from the lowest: compound 3; then compound 1; then compound 2.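

In this assay, among the compounds shown here, naphthalen-2-yl in place of phenyl on a saturated chain carbon bound to an amide-type nitrogen gives a 15-fold lower number from compound 2 to compound 3 (1.16 log units; beyond the scatter), which is the first reading of this change alone and shows that the activity responds strongly to the group at this position. For the compounds shown here, with naphthalen-2-yl held constant, hydrogen in place of methyl on a saturated chain carbon bound to an amide-type nitrogen and a carbonyl carbon gives a 6.7-fold lower number from compound 1 to compound 3 (0.83 log units; beyond the scatter), so compound 1, the only earlier compound bearing naphthalen-2-yl, did not show how low the number could go with that group present. The data shown give no reason for either step.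

The compounds shown leave open whether the two changes add up independently or depend on each other, a question that a phenyl compound carrying the methyl would address. They also leave open whether the trend continues beyond naphthalen-2-yl, for example with a biphenyl-4-yl or quinolinyl group at this position, and whether a free amine in place of the tert-butyl carbamate keeps the low number of compound 3.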